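Fluoro for chloro on the benzyl group of compound 3

The compounds below may be only part of what the source reports. "The series", "measured", "known", "first", "only" and "open" are said of these compounds alone.

In a functional assay on RAW264.7 cells (Mus musculus) for inhibition, read by Griess assay, with stated times of 2 h and 24 h (a higher number here means a weaker inhibitor, a lower number a stronger inhibitor), compound 1 `COc1ccc([C@@H]2CC(=O)c3c(O)cc(OCc4cn(Cc5ccc(C)cc5)nn4)cc3O2)cc1O` gives 16800 nM. Compound 2 `COc1ccc([C@@H]2CC(=O)c3c(O)cc(OCc4cn(Cc5cccc(C)c5)nn4)cc3O2)cc1O` gives 17400 nM, and compound 3 `COc1ccc([C@@H]2CC(=O)c3c(O)cc(OCc4cn(Cc5ccc(Cl)cc5)nn4)cc3O2)cc1O` gives 17800 nM. The three numbers sit together: a 1.0-fold higher number from compound 1 to compound 2 (0.02 log units; within the scatter), a 1.1-fold higher number from compound 1 to compound 3 (0.03 log units; within the scatter) and a 1.0-fold higher number from compound 2 to compound 3 (0.01 log units; within the scatter). Among the compounds with values here, compound 3 therefore stands within the scatter of both other compounds, and the series so far shows no substituent on that phenyl ring that moves the read-out.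

Compound 4 `COc1ccc([C@@H]2CC(=O)c3c(O)cc(OCc4cn(Cc5ccc(F)cc5)nn4)cc3O2)cc1O` differs from compound 3 by fluoro in place of chloro on an aromatic carbon. The most comparable step, the replacement of methyl by chloro on the same carbon, was a 1.1-fold higher number from compound 1 to compound 3 (0.03 log units; within the scatter), and the shift of methyl around the ring was a 1.0-fold higher number from compound 1 to compound 2 (0.02 log units; within the scatter); neither left the scatter. For compound 4 no step beyond the scatter is expected in this assay, that is a 1.0-fold lower number from compound 3 to compound 4 (0.01 log units; within the scatter). Compound 4 is estimated at 17500 nM, in a range from 9000 nM to 35000 nM.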

Compound 4, half-maximal inhibitory concentration: 15100 nM
Estimate against measurement, compound 4: 1.2-fold (0.06 log units) above; the measured number falls inside the stated range.
By their numbers in this assay, from the lowest: compounds 4, 1, 2 and 3 (each within the scatter of the next).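

In this assay, the exchange of halogen on this aromatic carbon stays within the scatter (a 1.2-fold lower number from compound 3 to compound 4 (0.07 log units; within the scatter)). The 4-fluorobenzyl group also cannot be separated from either methyl-substituted benzyl group (a 1.1-fold lower number from compound 1 to compound 4 (0.05 log units; within the scatter)) (a 1.2-fold lower number from compound 2 to compound 4 (0.06 log units; within the scatter)), so all four listed benzyl groups remain without a resolved order. No available evidence bears on why the read-out stays flat across these compounds.

On these data alone, whether an amine or a carboxylic acid on this phenyl ring would move the read-out remains open. So does the effect of a longer chain in place of the benzyl group.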